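The compounds below may be only part of what the source reports. "The series", "measured", "known", "first", "only" and "open" are said of these compounds alone.

Measured in a functional assay on the whole organism with Mus musculus as the target, in the rotarod test; a lower number here means that less compound is needed, a higher number that more compound is needed for the effect:
compound 1 `CC(=O)NCC(=O)Nc1ccc(Cl)cc1C(=O)c1ccccc1` — compound 1 gives > 100 mg/kg, a limit of the assay
compound 2 `CN1CCN(CC(=O)NCC(=O)N(C)c2ccc(Cl)cc2C(=O)c2ccccc2Cl)CC1` — compound 2 gives > 100 mg/kg, a limit of the assay
compound 3 `NCC(=O)NCC(=O)Nc1ccc([N+](=O)[O-])cc1C(=O)c1ccccc1` — compound 3 gives 24.8 mg/kg

Compound 2 stands only at a limit in this assay: its reading of > 100 mg/kg is a limit, not a number. Compound 1 likewise returns a limit, > 100 mg/kg. Both sit at the limit of > 100 mg/kg in this assay, at which 2 of the 3 values shown sit. Within the data shown here, compound 3 is the only measured compound with a number in this assay, 24.8 mg/kg. Among the measured compounds shown here, no pair of measured compounds differs in a single place, so no measured step is available.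

Compound 4, `CC(C)NCC(=O)NCC(=O)N(C)c1ccc(Cl)cc1C(=O)c1ccccc1Cl`, differs from compound 2 in one place: isopropylamino in place of 4-methylpiperazin-1-yl on a saturated chain carbon bound to a carbonyl carbon. The shared core is unchanged. Compound 2 is only a limit, so the size of the step to compound 4 in this assay cannot be anchored to a measured pair. A step toward lower dose is expected, since compound 3 gives 24.8 mg/kg. The step expected is an at least 1.6-fold lower number from compound 2 to compound 4 (0.22 log units; that floor lies within the scatter). There is a fair chance that the assay again returns only a limit for compound 4. For compound 4 a dose of 60 mg/kg is estimated, with a range of 15 mg/kg to 150 mg/kg.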

Compound 4, dose for half-maximal effect: 13 mg/kg
Estimate against measurement, compound 4: 4.6-fold (0.66 log units) above, and the stated range ends above it.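

In this assay, isopropylamino in place of 4-methylpiperazin-1-yl on a saturated chain carbon bound to a carbonyl carbon gives an at least 7.6-fold lower number from compound 2 to compound 4 (0.88 log units; beyond the scatter). Among these compounds, this is the first step that can be read: the group at this place alone separates a reading at the limit from a measured dose, with the rest of the structure unchanged. Only a floor can be given for the size of this step, as compound 2 is a limit and not a number: the limit of > 100 mg/kg in this assay, at which 2 of the 4 values shown sit.

The single change removes the ring, lowers the heavy-atom count and adds a hydrogen-bond donor all at once, so the compounds shown do not tell these apart. A dimethylamino or a piperidin-1-yl group on the same carbon would begin to separate them in this assay.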